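Cyanoethenyl for acetylethyl: the next toxicity read

The source may report more compounds than this note shows. Statements on the series, on what has been measured and on what is new or still open speak of the compounds shown alone.

Values in an ADME assay on MT2 cells (Homo sapiens) for cytotoxicity, read by XTT assay, with a stated time of 4 days; on this read-out higher numbers stand for lower toxicity in this test and lower numbers for higher toxicity in this test:
- compound 1 `Cc1cc(C#N)cc(C)c1Oc1ccc(N)c(Nc2ccc(C#N)cc2)n1`: > 100000 nM (a limit of the assay, not a number)
- compound 2 `Cc1cc(C#CC2CC2)cc(C)c1Oc1ccc(N)c(Nc2ccc(C#N)cc2)n1`: 5710 nM
- compound 3 `CC(=O)CCc1cc(C)c(Oc2ccc(N)c(Nc3ccc(C#N)cc3)n2)c(C)c1`: 18400 nM

Of the two true numbers, the upper one belongs to compound 3 at 18400 nM. The gap between the two is a 3.2-fold higher number from compound 2 to compound 3 (0.51 log units; beyond the scatter).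

The next change gives compound 4 `Cc1cc(/C=C/C#N)cc(C)c1Oc1ccc(N)c(Nc2ccc(C#N)cc2)n1`: 2-cyanoethenyl in place of 2-acetylethyl on an aromatic carbon. In words, 2-cyanoethenyl takes the place of 2-acetylethyl on an aromatic carbon.

Three measured steps at this same carbon bear on it. With 2-cyclopropylethynyl in place of cyano the step is large, an at least 17-fold lower number from compound 1 to compound 2 (1.24 log units; beyond the scatter). With 2-acetylethyl in place of cyano it is at least modest, an at least 5.4-fold lower number from compound 1 to compound 3 (0.73 log units; beyond the scatter). Both replacements of the cyano group of compound 1 moved the number down, and the two results differ only modestly.

Compound 4 also replaces that cyano group with a longer chain, so it is expected to fall near the span set by compound 2 at 5710 nM and compound 3 at 18400 nM. The expected step is a 2.3-fold lower number from compound 3 to compound 4 (0.36 log units; beyond the scatter), modest and toward a lower number.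

For compound 4 the estimated value is 8000 nM, with an expected range from 2500 nM to 28000 nM.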

Compound 4, half-maximal cytotoxic concentration: 5630 nM
Compound 4: middle estimate off by 1.4-fold (0.15 log units), on the high side; the range from low to high includes it.
By their numbers in this assay, from the lowest: compounds 4 and 2 (each within the scatter of the next); then compound 3. At a limit, above all of these: compound 1.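

Notes on this position: in this assay, the exchange of 2-acetylethyl for 2-cyanoethenyl gives a 3.3-fold lower number from compound 3 to compound 4 (0.51 log units; beyond the scatter), although both chains have no ring and the same hydrogen-bond acceptor count, so the read-out here depends on the type of chain and not only on the removal of cyano. The exchange of 2-cyclopropylethynyl for 2-cyanoethenyl gives a 1.0-fold lower number from compound 2 to compound 4 (0.01 log units; within the scatter), so two chains that differ in ring content and in their multiple bonds read alike, while compound 3, with its saturated link to the aromatic carbon, stays apart from both. Compound 1, whose cyano group also holds a triple bond, goes against any pattern tied to multiple bonds alone; its value is a limit and not a number, so an at least 17-fold lower number from compound 1 to compound 4 (1.24 log units; beyond the scatter) is only a bound: the limit of > 100000 nM in this assay, at which 1 of the 4 values shown sits.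

Open, on these data alone, is whether the double bond or the nitrile of 2-cyanoethenyl sets the read-out, which a saturated 2-cyanoethyl chain or a plain ethenyl group at this carbon would help to separate. Also open, as far as these compounds go, is how an amine or a carboxylic acid at the end of such a chain would read in this assay.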